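The compounds below may be only part of what the source reports. "The series", "measured", "known", "first", "only" and "open" are said of these compounds alone.

Working notes on the sulfonamide series.

Among the compounds with values here, compound 1 `CC1CCN(C2CCN(S(=O)(=O)c3cccc(-c4ccc(Cl)cc4)c3)CC2)CC1` gives the lowest number of the three measured so far: in a functional assay on DLD-1 cells (Homo sapiens) for antiproliferative activity, read by CellTiter-Glo, with a stated time of 72 h (a lower number here means a stronger inhibitor, a higher number a weaker inhibitor), compound 1 gives 15 nM. Compound 3 `COc1ccc(-c2ccc(S(=O)(=O)N3CCC(N4CCC(C)CC4)CC3)cc2)cc1` stands next, and in this assay compound 3 gives 263 nM, a step beyond the scatter. Compound 2 `Cc1ccc(C2CCN(S(=O)(=O)c3c(C)cc(C)cc3C)CC2)cc1` lies furthest away; in this assay compound 2 gives 2200 nM. On these numbers compound 1 is the strongest inhibitor of the set.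

Compound 4 `COc1cccc(S(=O)(=O)N2CCC(N3CCC(C)CC3)CC2)c1` is the next point, differing from compound 1 in one place: methoxy in place of 4-chlorophenyl on an aromatic carbon, on an aromatic carbon meta to a large group. Within the data shown here, no measured pair shows this change, so its size is not known. A loss of potency beyond the scatter is expected, as the step of a 27-fold higher number from compound 1 to compound 4 (1.43 log units; beyond the scatter) is estimated; the estimate for compound 4 is 400 nM, within 100 nM to 2000 nM.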

Compound 4, half-maximal inhibitory concentration: > 5000 nM
Compound 4 gave a limit, no number (the forecaster's own chance of this, stated with the estimate: 5%); middle value at least 12-fold (1.09 log units) from the limit.
By their numbers in this assay, from the lowest: compound 1; then compound 3; then compound 2. At a limit, above all of these: compound 4.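

Compound 4 gives a limit of the assay, not a number: the limit of > 5000 nM in this assay, at which 1 of the 4 values shown sits. Methoxy in place of 4-chlorophenyl gives an at least 330-fold higher number from compound 1 to compound 4 (2.52 log units; beyond the scatter), the first single-place step in the series, so the potency of compound 1 in this assay depends strongly on the group at this aromatic carbon. Only the minimum size of this step can be read.

What the compounds shown leave open is whether the ring or its chlorine carries the effect. An unsubstituted phenyl or a pyridine at this place would separate the two.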